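Acetyl to hydrogen in two cores: notes toward compound 4

A few compounds are considered here, and "the series" means these few. Any claim that something is new, unique, unknown or untested is made for them only; others in the source may bear on it.

Measured so far:
- compound 1 `COc1ccc(C2=C(c3cc(OC)c(OC)c(OC)c3)C(=O)C(OC(C)=O)C2)cc1`, 72 ug/mL in an ADME assay on KB cells (Homo sapiens) for cytotoxicity, read by MTT assay, with a stated time of 72 h; a lower number here means a stronger inhibitor, a higher number a weaker inhibitor
- compound 2 `COc1ccc(C2=C(c3cc(OC)c(OC)c(OC)c3)C(=O)C(O)C2)cc1`, which reaches a limit of this assay: < 1 ug/mL
- compound 3 `CC(=O)OC1C/C(=N/O)C(c2ccccc2)=C1c1ccccc1`, 9 ug/mL

Compound 1 and compound 2 differ only by hydrogen in place of acetyl on an oxygen on a saturated carbon; the step is an at least 72-fold lower number from compound 1 to compound 2 (1.85 log units; beyond the scatter). Compound 2 sits at the limit of < 1 ug/mL in this assay, at which 1 of the 3 values shown sits. Compound 3 gives a lower number than compound 1 in this assay. Compound 4 `O/N=C1/CC(O)C(c2ccccc2)=C1c1ccccc1` is not yet measured; it differs from compound 3 by hydrogen in place of acetyl on an oxygen on a saturated carbon, the same change at the same place as between compound 1 and compound 2. The difference between the core of compound 3 and the core of compound 1 is not broken down here. Resting on that single measured pair, a large step of the same kind is expected, and compound 4 is estimated at 0.6 ug/mL, meaning a 15-fold lower number from compound 3 to compound 4 (1.18 log units; beyond the scatter). The expected range for compound 4 runs from 0.1 ug/mL to 5 ug/mL, with a fair chance that this assay again reports only a limit.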

Compound 4, half-maximal inhibitory concentration: > 100 ug/mL
Compound 4: only a limit was reported (the forecaster's own chance of this, stated with the estimate: 55%); at least 160-fold (2.22 log units) between middle value and limit.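

On the core of compound 3, acetoxy to hydroxy gives an at least 11-fold higher number from compound 3 to compound 4 (1.04 log units; beyond the scatter), so the change does not carry from one core to another in this series as a fixed step. The two steps run in opposite directions in this assay: the same change on two cores in this assay, an at least 72-fold lower number (1.85 log units; beyond the scatter) from compound 1 to compound 2 and an at least 11-fold higher number (1.04 log units; beyond the scatter) from compound 3 to compound 4, at least 800-fold (2.90 log units) apart, beyond the scatter of two such steps. Compound 4 gives only a limit, > 100 ug/mL, and two pairs do not show which feature of the cores sets the direction of the step.

The compounds shown leave open whether the reversal goes with the oxime in place of the carbonyl or with the methoxy groups on the aryl rings, since the two cores differ in both. Also open, as far as these compounds go, is how an amine or a longer ester chain in place of the acetoxy group would read on either core.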